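A few compounds are considered here, and "the series" means these few. Any claim that something is new, unique, unknown or untested is made for them only; others in the source may bear on it.

Compound 1 `Cn1nc(-c2ccccc2)cc1-c1ccc2[nH]ccc2c1` and compound 2 `COc1ccc(-c2cc(-c3ccccc3)n[nH]2)cc1` have both been tested in a functional assay (Cortical neurone cells, Rattus norvegicus, strain Sprague-Dawley) for cytotoxicity, read by XTT assay, tested at 1 uM, in the presence of a further agent that is not named here; a higher number here means a weaker effect of the compound at the concentration tested, a lower number a stronger effect. Compound 1 gives 82.7% in this assay, and compound 2 gives 70.4%. Going by the values given here, of these two numbers, compound 2 is the lower one, and its gap to compound 1, the only other measured compound, lies beyond the usual scatter of repeated measurements, so compound 2 shows the stronger effect of the pair at the concentration tested. Compound 3 `Clc1ccc(-c2cc(-c3ccccc3)n[nH]2)cc1` has not yet been measured in this assay. Relative to compound 2, it carries chloro in place of methoxy on an aromatic carbon. Among the compounds with values here, no step between two measured compounds is available that would show how a change of this kind shifts the read-out, so the expectation for compound 3 rests on compound 2 alone. The change is expected to move the read-out only slightly, in no direction that would reach beyond the scatter, and the step is estimated as a number 1.6 percentage points higher from compound 2 to compound 3 (within the scatter). On that basis compound 3 is expected to give about 72% in this assay, within a range from 58% to 88%.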

Compound 3, a percentage reported as activity, at one concentration (the size of the read-out at that concentration, not a potency): 75%
Beside the measured number, compound 3's estimate is 3 percentage points below it; measured number inside the range.
By their numbers in this assay, from the lowest: compounds 2, 3 and 1 (each within the scatter of the next, the first and the last beyond it).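

Going by these compounds alone, this is the first step read at this place, on an aromatic carbon of the six-membered ring of carbon only, para to a large group. In this assay, chloro in place of methoxy gives a number 4.6 percentage points higher from compound 2 to compound 3 (within the scatter), so losing a carbon and oxygen pair, and with it the one hydrogen-bond acceptor of the group, in favour of a single chlorine does not separate the two compounds beyond the usual scatter. Nothing measured here bears on why the read-out stays this close across the exchange, and a single pair cannot show whether that holds for other groups at this carbon.

The compounds shown leave open whether a group of another kind at this same carbon, such as an amine, a carboxylic acid or a longer chain, would move the read-out beyond the scatter. Within the data shown here, they also leave open whether chloro in place of methoxy would behave in the same way on a core other than the one shared by compound 2 and compound 3.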